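The source may hold more compounds than are shown below. What is called first, only, known or untested is meant among the compounds shown, and "the series" means these compounds.

Of the compounds shown here, two have been measured in a functional assay on NCI-H460 cells (Homo sapiens) for cytotoxicity, read by sulforhodamine B assay, with a stated time of 48 h; a lower number here means a stronger inhibitor of growth, a higher number a weaker inhibitor of growth. Compound 1, `COC(=O)c1sc2cc(OC)ccc2c1C#Cc1ccccc1F`, gives 7200 nM in this assay, while compound 2, `COC(=O)c1sc2ccccc2c1C#Cc1ccccc1`, gives 64700 nM, the highest number of the two and well beyond the scatter from compound 1. The next compound is compound 3, `COC(=O)c1sc2ccccc2c1C#Cc1ccccc1F`, which differs from compound 2 by fluoro in place of hydrogen on an aromatic carbon. Compound 1 already carries this fluoro, together with a methoxy on the core, and compound 2 carries neither, so part of the gap may come from the fluoro. A step of moderate size toward a lower number is expected, a 2.6-fold lower number from compound 2 to compound 3 (0.41 log units; beyond the scatter). Compound 3 is therefore expected to give about 25000 nM in this assay, within a range of 8000 nM to 70000 nM.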

Compound 3, concentration for 50% growth inhibition: 25700 nM
Compound 3: middle estimate off by 1.0-fold (0.01 log units), on the low side; low and high end bracket the measured number.
By their numbers in this assay, from the lowest: compound 1; then compound 3; then compound 2.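

In this assay, the fluoro alone, as phenyl to 2-fluorophenyl, gives a 2.5-fold lower number from compound 2 to compound 3 (0.40 log units; beyond the scatter), so this single atom on the aromatic ring changes the number beyond the scatter. Removing the methoxy gives a 3.6-fold higher number from compound 1 to compound 3 (0.55 log units; beyond the scatter), which shows that the group on the core also counts, a contribution that compound 1 and compound 2 could not separate, as they differ in two places. What the compounds shown leave open is whether an amine or a carboxylic acid in place of the fluoro would lower the number further. Nothing available explains either step.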